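The compounds below may be only part of what the source reports. "The series", "measured", "known", "first", "only" and "open" are said of these compounds alone.

Of the compounds shown here, two built on a shared core have been measured in a physicochemical assay for solubility; a higher number here means a more soluble compound, a lower number a less soluble compound. Compound 1 `O=C(N[C@@H](CO)C(=O)NO)c1ccc(C#Cc2ccccc2)cc1` gives 28000 nM in this assay, while compound 2 `O=C(C[C@H](NC(=O)c1ccc(C#Cc2ccccc2)cc1)C(=O)NO)NCCCO` gives 82000 nM. For the measured compounds named here, compound 2 therefore holds the higher of the two numbers, and the only measured step is a 2.9-fold higher number from compound 1 to compound 2 (0.47 log units; beyond the scatter), which was brought about by putting (3-hydroxypropyl)carbamoyl in place of hydroxy on a saturated chain carbon, two bonds along the chain from an amide-type nitrogen and a carbonyl carbon.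

The next compound, compound 3 `CS(=O)(=O)C[C@H](NC(=O)c1ccc(C#Cc2ccccc2)cc1)C(=O)NO`, has not yet been measured. It differs from compound 2 at that same place: methylsulfonyl in place of (3-hydroxypropyl)carbamoyl on a saturated chain carbon, two bonds along the chain from an amide-type nitrogen and a carbonyl carbon. Going by the values given here, no measured compound carries a methylsulfonyl there, so the entering group is untested. The group that leaves is the very one whose arrival produced the step of a 2.9-fold higher number from compound 1 to compound 2 (0.47 log units; beyond the scatter), so its removal is expected to undo at least part of that rise; the step of a 2.7-fold lower number from compound 2 to compound 3 (0.44 log units; beyond the scatter) is expected to be a modest fall. Compound 3 is accordingly estimated at 30000 nM, with a likely range from 10000 nM to 90000 nM.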

Compound 3, solubility: 2000 nM
Compound 3: the middle estimate sits 15-fold (1.18 log units) above what was measured; the whole stated range lies above it.
By their numbers in this assay, from the lowest: compound 3; then compound 1; then compound 2.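

In this assay this position can now be seen to move the number in both directions, and much further than the earlier step suggested: methylsulfonyl in place of (3-hydroxypropyl)carbamoyl gives a 41-fold lower number from compound 2 to compound 3 (1.61 log units; beyond the scatter) and is the largest change among the three compounds. The fall does not stop at the level of the hydroxy group, as methylsulfonyl in place of hydroxy also gives a 14-fold lower number from compound 1 to compound 3 (1.15 log units; beyond the scatter) here, so taking away the (3-hydroxypropyl)carbamoyl is not simply a return to where compound 1 stands. Nothing measured here accounts for the size of this fall.

The two groups in this exchange differ in several ways at once, with 7 heavy atoms and 2 hydrogen-bond donors in (3-hydroxypropyl)carbamoyl against 4 heavy atoms and 0 hydrogen-bond donors in methylsulfonyl, and the three compounds cannot separate these differences. A sulfonamide carrying the same 3-hydroxypropyl chain would keep the sulfur group while restoring that chain, and a carboxylic acid or an amine at this place would show how far the number can move with other groups.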